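The source may hold more compounds than are shown below. What is called first, only, known or untested is meant among the compounds shown, and "the series" means these compounds.

Compound 1, `CC(C)CN1C(=O)c2ccccc2[C@H](C(=O)Nc2ccc(F)c(C#N)c2)[C@H]1C1CCCNC1`, gives 54000 nM in a physicochemical assay for solubility, in phosphate buffer, with a stated time of 18 h, at pH 7; on this read-out higher numbers stand for higher solubility and lower numbers for lower solubility.
Compound 2, `CC(C)CN1C(=O)c2ccccc2[C@H](C(=O)Nc2ccc(F)c(C#N)c2)[C@H]1c1ccc(C#N)s1`, gives 4900 nM in this assay.

Within the data shown here, compound 2 stands at the lower of these two numbers; the one measured step, an 11-fold lower number from compound 1 to compound 2 (1.04 log units; beyond the scatter), separates it from compound 1. Compound 3, `CC(C)CN1C(=O)c2ccccc2[C@H](C(=O)Nc2ccc(F)c(C#N)c2)[C@H]1c1ccc(C(N)=O)s1`, differs from compound 2 by carbamoyl in place of cyano on an aromatic carbon. Among the measured compounds shown here, no measured step covers this exchange; the only known step concerns a different part of the shared core, so it shows how far one change can move the number but gives no direction here. For compound 3 the expectation in this assay is a small rise, a 1.8-fold higher number from compound 2 to compound 3 (0.26 log units; within the scatter), within the usual scatter. Compound 3 is therefore estimated at 9000 nM, with a range from 3000 nM to 27000 nM.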

Compound 3, solubility: 19000 nM
Compound 3: the middle estimate sits 2.1-fold (0.32 log units) below what was measured, and the stated range covers the measured number.
By their numbers in this assay, from the lowest: compound 2; then compound 3; then compound 1.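

Changing the group on the five-membered aromatic ring with 1 sulfur, next to the ring sulfur, moves the number in this assay: carbamoyl in place of cyano gives a 3.9-fold higher number from compound 2 to compound 3 (0.59 log units; beyond the scatter), so this position responds to the group it carries. The exchange closes only part of the gap to the piperidin-3-yl compound, since a 2.8-fold lower number from compound 1 to compound 3 (0.45 log units; beyond the scatter) remains. Going by these compounds, whether an amine or a carboxylic acid at this position would shift the number further stays open. No measurement at hand explains why carbamoyl and cyano differ here.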